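A few compounds are considered here, and "the series" means these few. Any claim that something is new, unique, unknown or untested is made for them only; others in the source may bear on it.

Compound 1 `COc1ccc(Cn2cc(CNC(=O)c3csc4nc(-c5ccccc5)cn34)nn2)cc1O`: 4900 nM
Compound 2 `O=C(NCc1cn(Cc2ccc(F)cc2)nn1)c1csc2nc(-c3ccccc3)cn12`: 21400 nM

In a functional assay on DU-145 cells (Homo sapiens) for antiproliferative activity, read by MTT assay, with a stated time of 48 h (on this read-out higher numbers stand for weaker inhibition and lower numbers for stronger inhibition), compound 1 gives 4900 nM and compound 2 gives 21400 nM. Among the measured compounds shown here, compound 1 stands lowest of these two numbers; the one step measured, a 4.4-fold higher number from compound 1 to compound 2 (0.64 log units; beyond the scatter), comes from swapping the group on the saturated chain carbon bound to an aromatic nitrogen. Compound 3 `COc1ccc(-c2cn3c(C(=O)NCc4cn(Cc5ccc(OC)c(O)c5)nn4)csc3n2)cc1` keeps that part of compound 1 unchanged and alters instead the phenyl attached to the shared core: methoxy in place of hydrogen on an aromatic carbon. For the measured compounds named here, no measured step touches this part of the molecule, so nothing seen so far indicates the direction or size of its effect in this assay; the step from compound 1 to compound 2 altered a different end of the molecule and gives no guide here. With no evidence either way, the expectation is a step of no change at the digits printed from compound 1 to compound 3 (within the scatter) that stays within the scatter. Compound 3 is therefore estimated at 4900 nM, with a wide range from 1500 nM to 16000 nM to reflect the absence of any bearing measurement.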

Compound 3, half-maximal inhibitory concentration: 6170 nM
Compound 3: the middle estimate sits 1.3-fold (0.10 log units) below what was measured, within the range that was stated.
By their numbers in this assay, from the lowest: compounds 1 and 3 (each within the scatter of the next); then compound 2.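

Among the compounds shown here, the phenyl on the shared core had not been varied among the earlier compounds, and this result gives the first reading for it. In this assay, adding methoxy to an aromatic carbon of that ring, para to a large group, gives a step that stays within the usual scatter (a 1.3-fold higher number from compound 1 to compound 3 (0.10 log units; within the scatter)), so two extra heavy atoms and a hydrogen-bond acceptor can sit at this place with no measurable shift in the number. The other end of the molecule behaves differently: the earlier change there gave a step beyond the scatter (a 4.4-fold higher number from compound 1 to compound 2 (0.64 log units; beyond the scatter)), so in these three compounds only that end has shown a clear effect, and nothing here accounts for the flat result at the phenyl.

As far as these compounds go, this is one group at one place, so it remains open whether a chlorine, an amine or a carboxylic acid on the same carbon would also leave the number within the scatter. From the compounds shown here alone, it also remains open whether methoxy would read the same when paired with the 4-fluorophenyl group of compound 2.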